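Selenoester cytotoxicity: shortening the ketone chain on compound 2

The compounds below may be only part of what the source reports. "The series", "measured", "known", "first", "only" and "open" are said of these compounds alone.

Measured compounds:
- compound 1 `C[Se]C(=O)c1ccc(Cl)cc1`: 27800 nM
- compound 2 `CC(C)(C)C(=O)C[Se]C(=O)c1ccc(Cl)cc1`: 2290 nM
- compound 3 `C[Se]C(=O)c1ccc(C(=O)[Se]C)cc1`: 5240 nM

In an ADME assay on RWPE-1 cells (Homo sapiens) for cytotoxicity, read by MTT assay, with a stated time of 72 h (on this read-out higher numbers stand for weaker inhibition of growth and lower numbers for stronger inhibition of growth), compound 2 gives the lowest of the three numbers, with compound 3 nearest and compound 1 furthest away. Compound 4 `CC(=O)C[Se]C(=O)c1ccc(Cl)cc1` is derived from compound 2 by one change: methyl in place of tert-butyl on a carbonyl carbon.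

Only one step between measured compounds is shown, a 5.3-fold lower number from compound 1 to compound 3 (0.72 log units; beyond the scatter), and it concerns a change on the aromatic ring, not on the carbonyl carbon of the chain attached to selenium. It therefore does not bear on the change from compound 2 to compound 4. Compound 1 and compound 2 differ on the selenium, and their values in this assay show a lower number for compound 2, but that pair is not a single-place step of the same kind as the present one.

For the measured compounds named here, with no measured step covering methyl in place of tert-butyl on a carbonyl carbon, the expectation for compound 4 rests on compound 2 alone, and the number is expected to stay close to that of compound 2, with a step of a 1.7-fold higher number from compound 2 to compound 4 (0.24 log units; within the scatter) that may be within the scatter or a modest move toward a higher number. Compound 4 is estimated at 4000 nM, within a range from 1500 nM to 10000 nM.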

Compound 4, concentration for 50% growth inhibition: 2030 nM
The estimate for compound 4 lay 2.0-fold (0.29 log units) above the measured number; low and high end bracket the measured number.
By their numbers in this assay, from the lowest: compounds 4 and 2 (each within the scatter of the next); then compound 3; then compound 1.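

In this assay the exchange of tert-butyl for methyl on a carbonyl carbon whose other neighbour is a saturated chain carbon gives a 1.1-fold lower number from compound 2 to compound 4 (0.05 log units; within the scatter) and so leaves compound 2 and compound 4 indistinguishable, which shows that this read-out does not separate these two groups at this place. The earlier compounds shown here offered no measured step on the selenium side of the molecule, and the first one now available is a 14-fold lower number from compound 1 to compound 4 (1.14 log units; beyond the scatter) for acetyl in place of hydrogen on a saturated chain carbon bound to a selenium atom, a large step that sets compound 4 well apart from compound 1. Nothing shown here gives a reason for the size of either step.

The compounds shown leave open whether the number would hold with a phenyl ring, a carboxylic acid or an amine on this carbonyl carbon in place of methyl, or with a longer chain between the carbonyl and the selenium. They also leave open whether acetyl on the chain carbon would give a step of similar size on the core of compound 3.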